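The source may report more compounds than this note shows. Statements on the series, on what has been measured and on what is new or still open speak of the compounds shown alone.

Among the compounds with values here, compound 2 `CC1=C(C(C)C(=O)NCCN2CCCC2)c2cc(F)ccc2/C1=C\c1ccc([S+](C)[O-])cc1` holds the highest of the two numbers so far in a functional assay on PC-3 cells (Homo sapiens) for inhibition, read by CellTiter-Glo, with a stated time of 72 h (on this read-out lower numbers stand for higher toxicity in this test and higher numbers for lower toxicity in this test), giving 32000 nM; compound 1 `CC1=C(C(C)C(=O)N(CCNC(C)C)C(C)C)c2cc(F)ccc2/C1=C\c1ccc([S+](C)[O-])cc1` gives 15200 nM. Within the data shown here, the only measured step, a 2.1-fold higher number from compound 1 to compound 2 (0.32 log units; beyond the scatter), exchanged one amine-bearing substituent on the amide nitrogen for another and shifted the number modestly. Compound 3 `CC1=C(C(C)C(=O)NCCN2CCNCC2)c2cc(F)ccc2/C1=C\c1ccc([S+](C)[O-])cc1` differs from compound 2 by piperazin-1-yl in place of pyrrolidin-1-yl on a saturated chain carbon, two bonds along the chain from an amide-type nitrogen. Among the measured compounds shown here, no measured step covers exactly this exchange, but the single step seen suggests that changes at this amine end move the number only modestly. Compound 3 is therefore expected to give 30000 nM, within 10000 nM to 90000 nM, an expected step of a 1.1-fold lower number from compound 2 to compound 3 (0.03 log units; within the scatter).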

Compound 3, half-maximal cytotoxic concentration: > 50000 nM
Compound 3 was reported as a limit (the forecaster's own chance of this, stated with the estimate: 15%); middle value at least 1.6-fold (0.22 log units) from the limit.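

In this assay compound 3 is reported only as a limit, not as a number: the limit of > 50000 nM in this assay, at which 1 of the 3 values shown sits. As far as these compounds go, for piperazin-1-yl in place of pyrrolidin-1-yl (an at least 1.5-fold higher number from compound 2 to compound 3 (0.19 log units; that floor lies within the scatter)), the true size of the change stays unknown, and the floor alone does not show a shift beyond the scatter. The wider exchange of the whole amine side chain (an at least 3.2-fold higher number from compound 1 to compound 3 (0.51 log units; beyond the scatter)) does pass the scatter, even at its floor.

Still open, from the compounds shown here alone, is whether morpholin-4-yl or a dimethylamino group at this chain end would give a measurable number. Also open, going by these compounds, is how a longer chain would behave.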